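From Methoxy to Methoxycarbonyl on the Aromatic Ring

This account rests on a few compounds, and the source may have more. Where it says the series, first, only, none or still open, it means among the compounds named here.

In a functional assay on the whole organism for inhibition, with Cavia porcellus as the target (on this read-out lower numbers stand for an effect already at smaller amounts and higher numbers for an effect only at larger amounts of compound), compound 1 (`COc1ccccc1OCC1SCCN1C(=O)Cn1ccnc1`) gives 50 mg/kg and compound 2 (`COc1ccc(OCC2SCCN2C(=O)Cn2ccnc2)cc1`) gives 48 mg/kg on the same read-out. Compound 2 therefore stands level with compound 1, and the gap between them lies within the usual scatter of such measurements, so neither can be ranked over the other.

Compound 3 (`COC(=O)c1ccc(OCC2SCCN2C(=O)Cn2ccnc2)cc1`) has yet to be measured in this assay and departs from compound 2 at a single place. Methoxycarbonyl stands in place of methoxy on an aromatic carbon, para to a large group (methoxycarbonyl in place of methoxy on an aromatic carbon). Going by the values given here, no measured step in this small set shows what such a replacement does, so the expectation has only one starting point, compound 2 at 48 mg/kg in this test. A shift no larger than the scatter is expected, with a slight lean towards a higher number, and the estimated 1.1-fold higher number from compound 2 to compound 3 (0.06 log units; within the scatter) reflects that. The estimate for compound 3 is 55 mg/kg in this assay with an expected range of 22 mg/kg to 130 mg/kg on repeated measurement.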

Compound 3, dose for half-maximal effect: 62 mg/kg
Estimate against measurement, compound 3: 1.1-fold (0.05 log units) below; low and high end bracket the measured number.
By their numbers in this assay, from the lowest: compounds 2, 1 and 3 (each within the scatter of the next).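

On the aromatic carbon para to a large group, methoxycarbonyl in place of methoxy gives in this assay a 1.3-fold higher number from compound 2 to compound 3 (0.11 log units; within the scatter) and so does not separate the two compounds. The earlier compounds shown here carried only methoxy on the ring, so they could not show that this position accepts a group with more heavy atoms, a double bond outside the aromatic ring and an additional hydrogen-bond acceptor without a step beyond the scatter. No accompanying measurement bears on this result, so the step stands as an observation without an explanation.

Going by these compounds, it remains open whether a carboxylic acid, an amine or a longer chain on the same aromatic carbon would produce a step beyond the scatter in this assay or would likewise leave the number within it. Also open is whether methoxycarbonyl would give a similar result on the ring carbon that holds methoxy in compound 1, as the single step shown comes from one position and one pair of groups.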